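The source may hold more compounds than are shown below. What is called first, only, known or untested is meant among the compounds shown, and "the series" means these compounds.

Compound 2 `O=C1CCCN1c1cnc(NCc2c(F)ccc3c2CCO3)n2cnnc12` stands at the low end of the numbers gathered so far. In an ADME assay on microsomes from liver (Homo sapiens) for metabolic stability, read by LC-MS, using NADPH, with stated times of 5 min and 30 min, tested at 1 uM (on this read-out lower numbers stand for slow clearance and higher numbers for fast clearance), compound 2 gives only a limit, < 3 mL.min-1.g-1, rather than a number. Compound 1 `Cn1cc(-c2cnc(NCc3c(F)ccc4c3CCO4)c3cn[nH]c(=O)c23)cn1` and compound 3 `CNC(=O)c1ncc(-c2cnc(NCc3c(F)ccc4c3CCO4)c3cn[nH]c(=O)c23)n1C` share a core unlike that of compound 2; in this assay compound 1 gives 21 mL.min-1.g-1, and compound 3 gives 24 mL.min-1.g-1, so that a 1.1-fold higher number from compound 1 to compound 3 (0.06 log units; within the scatter). Compound 4 `O=C1CC2(CC2)CN1c1cnc(NCc2c(F)ccc3c2CCO3)n2cnnc12` differs from compound 2 in one place: a group of 8 heavy atoms (6 carbon, 1 nitrogen, 1 oxygen; one three-membered non-aromatic ring of carbon only, one five-membered non-aromatic ring with 1 hetero atom) in place of a group of 6 heavy atoms (4 carbon, 1 nitrogen, 1 oxygen; one five-membered non-aromatic ring with 1 hetero atom), on an aromatic carbon. Among the compounds with values here, no measured step bears directly on this change; the one step seen, from compound 1 to compound 3, concerns another core and another position and stayed within the scatter. Since compound 2 rests at the limit of < 3 mL.min-1.g-1 in this assay, at which 1 of the 3 values shown sits, no drop could be resolved, and any rise would have to pass the limit before it showed. Compound 4 is therefore expected to stay near the limit, with a number no lower from compound 2 to compound 4 (the limit leaves the size open) as the expected step. The estimate for compound 4 is 3 mL.min-1.g-1, within a range from 1.5 mL.min-1.g-1 to 8 mL.min-1.g-1.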

Compound 4, intrinsic clearance in microsomes: < 3 mL.min-1.g-1
Compound 4: only a limit was reported; the forecaster's own chance of this, stated with the estimate: 55%; the middle value lies on the limit itself.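

In this assay, within the data shown here, compound 2 and compound 4 both give only a limit, so no step between them can be read: the limit of < 3 mL.min-1.g-1 in this assay, at which 2 of the 4 values shown sit. The compounds shown leave open what clearance lies behind each limit, and whether the added three-membered carbon ring changes it at all.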